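Carboxy in place of ethoxy on a diphenyl sulfide imidazoline

This account rests on a few compounds, and the source may have more. Where it says the series, first, only, none or still open, it means among the compounds named here.

Measured so far:
compound 1 `CC/N=C(\N)Nc1ccc(Sc2ccc(OC)cc2)cc1` — 251 nM
compound 2 `c1ccc(Sc2ccc(NC3=NCCN3)cc2)cc1` — 794 nM
compound 3 `CCOc1ccc(Sc2ccc(NC3=NCCN3)cc2)cc1` — 39.8 nM

In an assay (Rattus norvegicus) for binding affinity to prostacyclin receptor (Homo sapiens), read by radioligand binding (a lower number here means a stronger inhibitor, a higher number a weaker inhibitor), compound 3 gives the lowest of the three numbers; compound 1 lies 251 nM and compound 2 lies 794 nM. Within the data shown here, the step of a 20-fold lower number from compound 2 to compound 3 (1.30 log units; beyond the scatter) is the only one-place step among them. Compound 4 `O=C(O)c1ccc(Sc2ccc(NC3=NCCN3)cc2)cc1` differs from compound 3 by carboxy in place of ethoxy on an aromatic carbon. Among the measured compounds shown here, no measured step exchanges one substituent for another at this position; the step from compound 2 to compound 3 shows only that a group there matters, not which. The writer therefore expects for compound 4 a moderate rise, a 3.0-fold higher number from compound 3 to compound 4 (0.48 log units; beyond the scatter), and estimates 120 nM with a range from 25 nM to 600 nM.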

Compound 4, inhibition constant: < 10000 nM
Compound 4 ended at the assay's limit; the forecaster's own chance of this, stated with the estimate: 5%; the middle value lies beyond the limit too.
By their numbers in this assay, from the lowest: compound 3; then compound 1; then compound 2.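

In this assay compound 4 gives < 10000 nM, which is a limit of the assay and not a number. Among these compounds, no step from compound 2 or compound 3 to compound 4 can be read. The compounds shown leave open how much carboxy differs from ethoxy or hydrogen at this position.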